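Trading Chloro for Methoxy in an Orexin Receptor Series

The source may hold more compounds than are shown below. What is called first, only, known or untested is meant among the compounds shown, and "the series" means these compounds.

Measured compounds:
- Compound 1, `COc1ccc(N2C(=O)N(Cc3c(F)cc(F)cc3F)c3ccccc3S2(=O)=O)cc1OC`, in an assay on isolated protein for displacement of a labelled ligand from Orexin/Hypocretin receptor type 1 (Homo sapiens), with a stated time of 90 min (on this read-out lower numbers stand for stronger inhibition and higher numbers for weaker inhibition), compound 1 gives 50.1 nM.
- Compound 2, `COc1ccc(N2C(=O)N(Cc3c(F)cc(F)cc3Cl)c3ccccc3S2(=O)=O)cc1OC`, in this assay compound 2 gives 25.1 nM.

Compound 2 has the lowest number of the two measured, yet it does not stand apart from compound 1: the step of a 2.0-fold lower number from compound 1 to compound 2 (0.30 log units; within the scatter) is within the usual scatter, so the two compounds count as indistinguishable on this read-out.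

Compound 3, `COc1ccc(N2C(=O)N(Cc3c(F)cc(F)cc3OC)c3ccccc3S2(=O)=O)cc1OC`, has not yet been measured. It differs from compound 2 in one place: methoxy in place of chloro on an aromatic carbon. Within the data shown here, the only measured step concerns a different exchange, fluoro to chloro at the same position, and it was a 2.0-fold lower number from compound 1 to compound 2 (0.30 log units; within the scatter), a change too small to trust. The change to compound 3 introduces a different kind of group, so that step gives only weak guidance. The expectation is therefore a step of a 1.6-fold higher number from compound 2 to compound 3 (0.20 log units; within the scatter), no shift beyond the scatter, in either direction. Compound 3 is expected to give 40 nM in this assay, within a range from 12 nM to 130 nM.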

Compound 3, inhibition constant: 63.1 nM
Beside the measured number, compound 3's estimate is 1.6-fold (0.20 log units) below it; low and high end bracket the measured number.
By their numbers in this assay, from the lowest: compounds 2, 1 and 3 (each within the scatter of the next, the first and the last beyond it).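

In this assay, among these compounds, the group at this spot on the benzyl ring can matter: a 2.5-fold higher number from compound 2 to compound 3 (0.40 log units; beyond the scatter) is a modest step, but it is the first to clear the usual scatter. The comparison with fluoro reads differently, since a 1.3-fold higher number from compound 1 to compound 3 (0.10 log units; within the scatter) stays within the scatter, so compound 1 and compound 3 cannot be told apart, and only chloro and methoxy are separated, with fluoro indistinguishable from either. The exchange puts two heavy atoms and one hydrogen-bond acceptor where chloro had one heavy atom and no acceptor, but the data offer nothing that explains why the number moves with this change.

Among the compounds shown here, with only three groups compared at one position, a single modest step cannot show a trend, so it remains open how a longer chain such as ethoxy, a hydroxyl group or an amine would behave there. Going by these compounds, it is equally open whether methoxy in place of chloro would give a similar step on a different core, or whether the step is particular to the 2,4-difluoro-6-methoxybenzyl group seen here.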